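Amide and ester variants on the shared core: inhibition notes

This account rests on a few compounds, and the source may have more. Where it says the series, first, only, none or still open, it means among the compounds named here.

Measured so far, all in an assay on a protein complex for inhibition of CDK8/Cyclin C (Homo sapiens), with a stated time of 1 h, tested at 10 uM; a lower number here means less inhibition, a higher number more inhibition at the concentration tested (going by the name of the read-out):
- compound 1 `CCOC(=O)/C=C/c1ccncc1-c1ccc2c(ccn2C)c1` gives 100%
- compound 2 `COC1CN(C(=O)/C=C/c2ccncc2-c2ccc3ccccc3c2)C1` gives 100%
- compound 3 `CNC(=O)CCc1ccncc1-c1ccc2ccccc2c1` gives 100%

Compound 2 stands level with compound 1 and compound 3 at the digits reported; the differences to both lie within the scatter of this kind of measurement, so no order among the three can be read from these numbers. Whatever distinguishes the ester of compound 1, the saturated methylamide of compound 3 and the ring amide of compound 2, it leaves the read-out saturated at the concentration tested.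

Not yet measured is compound 4 `O=C(O)[C@@H]1CCCN1C(=O)/C=C/c1ccncc1-c1ccc2ccccc2c1`. Relative to compound 2 the change is 2-carboxypyrrolidin-1-yl in place of 3-methoxyazetidin-1-yl on a carbonyl carbon. The carbonyl carbon bearing the ring amide keeps its double-bonded chain carbon neighbour; only the ring on the nitrogen changes, from a four-membered ring with one hetero atom to a five-membered ring with one hetero atom carrying a carboxy group and one defined stereocentre.

For the measured compounds named here, no step between measured compounds is known, so the size of any step in this assay is itself unknown. Given that three different groups at this position all reach the same saturated read-out, the step from compound 2 to compound 4 is expected to be none beyond the scatter, or at most a small loss. The step of a number 5 percentage points lower from compound 2 to compound 4 (within the scatter) is therefore estimated to be small. Compound 4 is expected to give 95%, with a range of 80% to 100%.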

Compound 4, a percentage reported as inhibition, at one concentration (the size of the read-out at that concentration, not a potency): 67%
Estimate against measurement, compound 4: 28 percentage points above; the whole stated range lies above it.
By their numbers in this assay, from the lowest: compound 4; then compounds 1, 2 and 3 (each within the scatter of the next).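

Replacing 3-methoxyazetidin-1-yl with 2-carboxypyrrolidin-1-yl on a carbonyl carbon produces a clear drop in this assay, with a step of a number 33 percentage points lower from compound 2 to compound 4 (beyond the scatter). For the compounds shown here, the group on this carbonyl carbon is therefore not a free choice, a sensitivity that the identical top read-outs of the earlier compounds could not reveal, and the series can fall away from that ceiling at the concentration tested. The change alters the ring size and brings in both a carboxy group and a defined stereocentre in a single step, so the loss cannot be divided among these features, and no available data account for it.

Still open, as far as these compounds go, is whether the loss follows the carboxy group, the five-membered ring or the stereocentre: a plain pyrrolidin-1-yl amide, a methyl ester or primary amide in place of the carboxylic acid, and the opposite configuration at the stereocentre would each separate these features. Whether 3-methoxyazetidin-1-yl itself holds any margin over other amides also remains unresolved, as a read-out at the ceiling at a single concentration gives no potency.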